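The source may report more compounds than this note shows. Statements on the series, on what has been measured and on what is new or still open speak of the compounds shown alone.

In an assay on HEK293 cells for inhibition of Voltage-dependent T-type calcium channel subunit alpha-1G (Homo sapiens), read by patch clamp, tested at 10 uM (a lower number here means less inhibition, a higher number more inhibition at the concentration tested (going by the name of the read-out)), compound 1 `O=C(CCCN1CCN(c2ccccc2)CC1)Nc1ccc(Cl)cc1` gives 75.1%. Going by the values given here, compound 2 `O=C(CCCN1CCN(c2ccc(F)cc2)CC1)Nc1ccc(Cl)cc1`, which carries fluoro in place of hydrogen on an aromatic carbon, gives 76.1% in this assay, and the step of a number 1 percentage points higher from compound 1 to compound 2 (within the scatter) lies within the scatter, so compound 1 stands level with the only other measured compound. Compound 3 `O=C(CCCN1CCN(c2ccccc2)CC1)Nc1ccc(Cl)cc1Cl` differs from compound 1 by chloro in place of hydrogen on an aromatic carbon, or, cut one bond further out, 4-chlorophenyl to 2,4-dichlorophenyl. Among the compounds with values here, only that one measured step bears on this change, and it was flat, so compound 3 is expected to show no step beyond the scatter, a number 0.1 percentage points lower from compound 1 to compound 3 (within the scatter). The estimate for compound 3 in this assay is 75%, expected between 55% and 90%.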

Compound 3, a percentage reported as inhibition, at one concentration (the size of the read-out at that concentration, not a potency): 76.2%
For compound 3 the middle estimate is 1.2 percentage points below the measured one; low and high end bracket the measured number.
By their numbers in this assay, from the lowest: compounds 1, 2 and 3 (each within the scatter of the next).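

Adding a chloro ortho to a large group and meta to a chloro group, turning 4-chlorophenyl into 2,4-dichlorophenyl, gives a number 1.1 percentage points higher from compound 1 to compound 3 (within the scatter) in this assay. So this position, on a different aromatic ring from the fluoro change, also accepts a single halogen without a step beyond the scatter. No available measurement bears on why this result is flat. Still open, on these data alone, is whether a hydroxyl group or an amine at this position, or a longer chain joining the two halves of the molecule, would shift the inhibition beyond the scatter.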